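The source may hold more compounds than are shown below. What is called first, only, known or untested is meant among the compounds shown, and "the series" means these compounds.

Measured in a functional assay on CCRF-CEM cells (Homo sapiens) for cytotoxicity, read by MTT assay, with a stated time of 72 h; on this read-out higher numbers stand for weaker inhibition and lower numbers for stronger inhibition:
compound 1 `Cc1ccc(NN=C(c2nc3ccccc3[nH]2)c2nc3ccccc3[nH]2)cc1`: 87600 nM
compound 2 `COc1ccc(NN=C(c2nc3ccccc3[nH]2)c2nc3ccccc3[nH]2)cc1`: 96700 nM

Among the measured compounds shown here, compound 1 and compound 2 sit within the scatter of each other in this assay; the step of a 1.1-fold higher number from compound 1 to compound 2 (0.04 log units; within the scatter) is the only measured step. Compound 3 `O=[N+]([O-])c1ccc(NN=C(c2nc3ccccc3[nH]2)c2nc3ccccc3[nH]2)cc1` is not yet measured. Its change from compound 1: nitro in place of methyl on an aromatic carbon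

For the measured compounds named here, no measured step involves a nitro group, so the methoxy-for-methyl step is the only guide, and it was within the scatter. Compound 3 is therefore expected to show a step of a 1.1-fold lower number from compound 1 to compound 3 (0.04 log units; within the scatter) in this assay that does not exceed the scatter. The estimate for compound 3 is 80000 nM, with a range from 30000 nM to 200000 nM.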

Compound 3, half-maximal inhibitory concentration: 140000 nM
Estimate against measurement, compound 3: 1.8-fold (0.24 log units) below; measured number inside the range.
By their numbers in this assay, from the lowest: compounds 1, 2 and 3 (each within the scatter of the next).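

In this assay a nitro group on this aromatic carbon, para to a large group, stays within the scatter of both earlier groups (a 1.6-fold higher number from compound 1 to compound 3 (0.20 log units; within the scatter); a 1.4-fold higher number from compound 2 to compound 3 (0.16 log units; within the scatter)). Methyl, methoxy and nitro thus give no step beyond the scatter here, even though nitro brings 3 heavy atoms and 2 hydrogen-bond acceptors where methyl has 1 heavy atom and none. No evidence at hand bears on this result. From the compounds shown here alone, whether an amine or a carboxylic acid at this position would give a step beyond the scatter stays open, as do changes to the shared core.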